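This account rests on a few compounds, and the source may have more. Where it says the series, first, only, none or still open, it means among the compounds named here.

Compound 1 `CCCCCCCCCCc1ccc(-c2noc(CCCCN)n2)cc1`: 55%
Compound 2 `CCCCCCCCCCc1ccc(-c2noc(CCCN3CCCCC3)n2)cc1`: 0%

Among the compounds with values here, in an assay on HeLa cells for inhibition of sphingosine-1-phosphate transporter SPNS2 (Mus musculus), read by LC-MS, tested at 2 uM (a higher number here means more inhibition at the concentration tested (going by the name of the read-out), a lower number less inhibition), compound 2 gives the lower of the two numbers, with compound 1 the only neighbour; the one measured step, a number 55 percentage points lower from compound 1 to compound 2 (beyond the scatter), is large. Compound 3 `CCCCCCCCCCc1ccc(-c2noc(CC(O)CNCC)n2)cc1` has not been measured. It differs from compound 2 by 2-(ethylamino)-1-hydroxyethyl in place of 2-(piperidin-1-yl)ethyl on a saturated chain carbon bound to an aromatic carbon. The step from compound 1 to compound 2 bears on this change, as it replaced an open-chain amine with the same ring amine that now leaves again, and it was large. For compound 3 a rise is therefore expected, a number 30 percentage points higher from compound 2 to compound 3 (beyond the scatter), though short of compound 1. Compound 3 is estimated at 30%, between 5% and 60%.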

Compound 3, a percentage reported as inhibition, at one concentration (the size of the read-out at that concentration, not a potency): 5%
Compound 3: the middle estimate sits 25 percentage points above what was measured, and the stated range covers the measured number.
By their numbers in this assay, from the lowest: compounds 2 and 3 (each within the scatter of the next); then compound 1.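

In this assay, the open-chain 3-(ethylamino)-2-hydroxypropyl group in place of 3-(piperidin-1-yl)propyl gives a number 5 percentage points higher from compound 2 to compound 3 (within the scatter) and so does not restore the reading of compound 1. Set against the 3-aminopropyl-bearing chain of compound 1, the change gives a number 50 percentage points lower from compound 1 to compound 3 (beyond the scatter), which shows that among these three compounds an open-chain amine alone does not suffice at this position. No measurement shown accounts for this result. Still open, as far as these compounds go, is how 3-(ethylamino)propyl, without the hydroxyl, and 3-amino-2-hydroxypropyl, without the ethyl, would read, which would separate the two features.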